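A few compounds are considered here, and "the series" means these few. Any claim that something is new, unique, unknown or untested is made for them only; others in the source may bear on it.

Working notes on the series. Of the compounds shown here, two have been measured in a functional assay on CHO cells for antagonist activity at prostaglandin E2 receptor EP3 subtype (Homo sapiens), read by cAMP accumulation (on this read-out higher numbers stand for weaker inhibition and lower numbers for stronger inhibition), so far, and they share the core seen in compound 1 `CC(C)C(c1ccc(-c2ccc3cccc(F)c3c2)[nH]c1=O)N1CCN/C1=N\C#N` and compound 2 `CC(C)C(c1ncc[nH]1)c1ccc(-c2ccc3cccc(F)c3c2)[nH]c1=O`. In this assay compound 1 gives 38 nM. In this assay compound 2 gives 33 nM. The step of a 1.2-fold lower number from compound 1 to compound 2 (0.06 log units; within the scatter) lies within the scatter, so compound 2 holds the lower of the two numbers without being separable from compound 1; no claim of order follows from these two values.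

Compound 3 `CC(C)C(/C=C1/CCNC1=O)c1ccc(-c2ccc3cccc(F)c3c2)[nH]c1=O` is the next member. Relative to compound 2 the change is a group of 7 heavy atoms (5 carbon, 1 nitrogen, 1 oxygen; one five-membered non-aromatic ring with 1 hetero atom) in place of a group of 5 heavy atoms (3 carbon, 2 nitrogen; one five-membered aromatic ring with 2 hetero atoms), on a saturated chain carbon bound to an aromatic carbon and a saturated chain carbon. Within the data shown here, only one measured step touches this position, a 1.2-fold lower number from compound 1 to compound 2 (0.06 log units; within the scatter), which exchanged a five-membered non-aromatic ring with 2 hetero atoms for a five-membered aromatic ring with 2 hetero atoms and moved the number only within the scatter. Among the measured compounds shown here, the change to compound 3 again replaces the group at this saturated chain carbon, now with a five-membered non-aromatic ring with 1 hetero atom carrying 2 double bonds outside aromatic rings; the single comparable step gives no ground to expect movement beyond the scatter in this assay, though the incoming group has no measured precedent here, so the range is kept wide. Compound 3 is therefore expected at 40 nM, with a range of 14 nM to 120 nM, a step of a 1.2-fold higher number from compound 2 to compound 3 (0.08 log units; within the scatter) expected from compound 2.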

Compound 3, half-maximal inhibitory concentration: 8.1 nM
The estimate for compound 3 lay 4.9-fold (0.69 log units) above the measured number, outside the stated range (below it).
By their numbers in this assay, from the lowest: compound 3; then compounds 2 and 1 (each within the scatter of the next).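

In this assay this saturated chain carbon, bound to an aromatic carbon and a saturated chain carbon, proves sensitive to the group it carries, which the earlier exchange, confined to the scatter, did not show. The group with a five-membered non-aromatic ring with 1 hetero atom and 2 double bonds outside aromatic rings gives a 4.1-fold lower number from compound 2 to compound 3 (0.61 log units; beyond the scatter) and also a 4.7-fold lower number from compound 1 to compound 3 (0.67 log units; beyond the scatter) so compound 3 stands apart from both earlier compounds, and the two steps are of similar size whichever group it replaces. Nothing on hand bears on why the group has this effect.

The compounds shown cannot tell which feature of the entering group goes with the lower number, since its ring, its carbonyl and its double bond outside the ring all enter together in a single change. They also leave open how far this position tolerates other kinds of group, such as an amine, a carboxylic acid or a longer chain on the same saturated chain carbon, and whether any of these would match or pass compound 3 in this assay on the shared core.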